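The source may hold more compounds than are shown below. What is called first, only, known or untested is meant among the compounds shown, and "the series" means these compounds.

Of the compounds shown here, three built on one shared core have been measured in a functional assay on HepG2 cells (Homo sapiens) for inhibition, read by MTT assay, with a stated time of 72 h; on this read-out lower numbers stand for stronger inhibition and higher numbers for weaker inhibition. Compound 1 `CN(C(=O)NC(=O)c1ccc(Cl)cc1Cl)c1nc(C(F)(F)F)c(C(=O)N/N=C/c2ccc(C(F)(F)F)cc2)s1` gives 12.4 ug/mL. Compound 2 `CN(C(=O)NC(=O)c1cccc(C(F)(F)F)c1)c1nc(C(F)(F)F)c(C(=O)N/N=C/c2ccccc2C(F)(F)F)s1` gives 10.4 ug/mL, and compound 3 `CN(C(=O)NC(=O)c1ccc(F)c(F)c1)c1nc(C(F)(F)F)c(C(=O)N/N=C/c2ccccc2C(F)(F)F)s1` gives 10.4 ug/mL. Compound 3 thus stands level with compound 2, and its gap to compound 1 is within the scatter. For the measured compounds named here, the only measured single step, no change at the digits printed from compound 2 to compound 3 (within the scatter), changed the group on a carbonyl carbon and lies within the scatter. Compound 4 `CN(C(=O)NC(=O)c1ccc(F)c(F)c1)c1nc(C(F)(F)F)c(C(=O)N/N=C/c2cccc(C(F)(F)F)c2)s1` differs from compound 3 by 3-(trifluoromethyl)phenyl in place of 2-(trifluoromethyl)phenyl on a carbon with a double bond to nitrogen. Going by the values given here, no measured step touches this carbon alone; compounds 1 and 2, which differ there and elsewhere, show values within the scatter of each other. Compound 4 is therefore expected to move little, a 1.0-fold higher number from compound 3 to compound 4 (0.00 log units; within the scatter). Compound 4 is estimated at 10.5 ug/mL, between 6 ug/mL and 18 ug/mL.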

Compound 4, half-maximal inhibitory concentration: 5.6 ug/mL
The estimate for compound 4 lay 1.9-fold (0.27 log units) above the measured number; the measured number lies below the stated range.
By their numbers in this assay, from the lowest: compounds 4, 2, 3 and 1 (each within the scatter of the next, the first and the last beyond it).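

For the compounds shown here, this is the first step that changes only the carbon with a double bond to nitrogen: in this assay, 3-(trifluoromethyl)phenyl in place of 2-(trifluoromethyl)phenyl gives a 1.9-fold lower number from compound 3 to compound 4 (0.27 log units; within the scatter). The two groups have the same atoms, so this pair isolates the placement of the trifluoromethyl group, and on this single pair that placement does not clear the scatter. Nothing available explains the step.

As far as these compounds go, whether a phenyl carrying an amine or a carboxylic acid in this place would give a step beyond the scatter remains open. So does whether the same swap would read alike with a different group on the carbonyl carbon.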